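Replacing pyridin-3-yl by 2,4-dichlorophenyl on the amide

The compounds below may be only part of what the source reports. "The series", "measured", "known", "first", "only" and "open" are said of these compounds alone.

Three amides built on one shared core have been tested in a functional assay on MCF7 cells (Homo sapiens) for antiproliferative activity, read by MTT assay, with a stated time of 72 h; a lower number here means a stronger inhibitor, a higher number a weaker inhibitor. Compound 1 `O=C(Nc1ccc(Cl)c(-c2nnc3c(Cl)cccn23)c1)c1ccc(C(F)(F)F)cc1Cl` carries chloro and trifluoromethyl on the ring attached to the carbonyl carbon, and in this assay compound 1 gives 81600 nM. Compound 3 `O=C(Nc1ccc(Cl)c(-c2nnc3c(Cl)cccn23)c1)c1ccc(C(F)(F)F)cc1F` differs only by fluoro in place of chloro on an aromatic carbon, and compound 3 gives 62800 nM. The step of a 1.3-fold lower number from compound 1 to compound 3 (0.11 log units; within the scatter) is therefore too small to be trusted as a real change. Compound 2 `O=C(Nc1ccc(Cl)c(-c2nnc3c(Cl)cccn23)c1)c1cccnc1` carries pyridin-3-yl on the carbonyl carbon. For compound 2 this assay reports only a limit, > 100000 nM. Compound 2 thus stands at the limit of > 100000 nM in this assay, at which 1 of the 3 values shown sits, and no number is known for it.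

Compound 4 `O=C(Nc1ccc(Cl)c(-c2nnc3c(Cl)cccn23)c1)c1ccc(Cl)cc1Cl` comes next; the change from compound 2 is 2,4-dichlorophenyl in place of pyridin-3-yl on a carbonyl carbon. Among the measured compounds shown here, no measured step covers this exchange, and compound 2 offers only a limit to start from. What the data show is that the two measured amides with a six-membered aromatic ring of carbon only, compound 1 and compound 3, both give high numbers, and compound 4 carries a ring of that kind. Compound 4 is therefore expected to land near them, with an estimated value of 80000 nM in this assay, within a range from 30000 nM to 200000 nM. The expected step of an at least 1.2-fold lower number from compound 2 to compound 4 (0.09 log units; that floor lies within the scatter) is only an estimate, since it starts from a limit.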

Compound 4, half-maximal inhibitory concentration: 78200 nM
For compound 4 the middle estimate is 1.0-fold (0.01 log units) above the measured one, within the range that was stated.
By their numbers in this assay, from the lowest: compounds 3, 4 and 1 (each within the scatter of the next). At a limit, above all of these: compound 2.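

At the carbonyl carbon, the exchange of pyridin-3-yl for 2,4-dichlorophenyl can now be given a size in this assay, as a floor rather than a full step (an at least 1.2-fold lower number from compound 2 to compound 4 (0.10 log units; that floor lies within the scatter)) and with no demonstrated gain in activity. Compound 2 remains a limit of the assay and not a number: the limit of > 100000 nM in this assay, at which 1 of the 4 values shown sits. On the ring attached to the carbonyl carbon, chloro in place of trifluoromethyl also leaves no readable change (a 1.0-fold lower number from compound 1 to compound 4 (0.02 log units; within the scatter)), so this second exchange on compound 1 behaves like the fluoro for chloro exchange seen earlier.

The compounds shown carry only chloro, fluoro and trifluoromethyl on a ring of carbon only, so it stays open whether an amine, a carboxylic acid or a methoxy group on that ring would give a clearly lower number. On these data alone, the true distance between pyridin-3-yl and 2,4-dichlorophenyl also stays unknown as long as compound 2 has only a limit.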